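Dichloroacetamides on a biphenyl core: a methyl replaces phenyl

The source may report more compounds than this note shows. Statements on the series, on what has been measured and on what is new or still open speak of the compounds shown alone.

Measured compounds:
compound 1 `COC(=O)c1ccc(-c2cccc(NC(=O)C(Cl)Cl)c2)cc1` — > 50000 nM
compound 2 `O=C(Nc1cccc(-c2ccc(-c3ccccc3)cc2)c1)C(Cl)Cl` — > 50000 nM
compound 3 `O=C(Nc1cccc(-c2ccccc2Cl)c1)C(Cl)Cl` — > 50000 nM

The three compounds were tested in a functional assay on KB 3-1 cells (Homo sapiens) for cytotoxicity, read by MTT assay, with a stated time of 68 h; on this read-out higher numbers stand for weaker inhibition and lower numbers for stronger inhibition. Each carries the same dichloroacetamide on a shared core, differing only in the group attached to the far ring. In this assay compound 1 gives only a limit, > 50000 nM. Compound 2 likewise gives only a limit, > 50000 nM. Compound 3 also gives only a limit, > 50000 nM. All three readings thus sit at the same limit, (the limit of > 50000 nM in this assay, at which 3 of the 3 values shown sit), and no number is known for any of them.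

Going by the values given here, the one step between measured compounds that differ in a single place, a step that the two limits leave unreadable from compound 1 to compound 2, cannot be read, since both ends are limits. The unmeasured compound 4 `Cc1ccc(-c2cccc(NC(=O)C(Cl)Cl)c2)cc1` is reached from compound 2 by methyl in place of phenyl on an aromatic carbon. Among the compounds with values here, no measured step bears on this change, and none of the three readings gives a number to move from, so there is no basis to expect any step beyond the scatter in this assay in either direction. The expectation is therefore that compound 4 will again give only a limit, with an estimated value of 50000 nM in a range of 25000 nM to 100000 nM, an expected step of a number no higher from compound 2 to compound 4 (the limit leaves the size open).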

Compound 4, half-maximal inhibitory concentration: > 50000 nM
Compound 4: only a limit was reported; the forecaster's own chance of this, stated with the estimate: 85%; the middle value sits exactly at the limit.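

No new step can be read, since compound 4, like compound 1 and compound 2, gives only a limit, so its differences from those two have no readable size: the limit of > 50000 nM in this assay, at which 4 of the 4 values shown sit. The compounds shown leave open whether any group on the far ring would give an actual number in this assay at all.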